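This account rests on a few compounds, and the source may have more. Where it says the series, first, only, none or still open, it means among the compounds named here.

Measured compounds:
compound 1, `CN(C)C(=O)c1cc2cnc(Nc3ccc(C(=O)NCCCCCCN=C=S)cc3)nc2n1C1CCCC1` — 100%
compound 2, `CN(C)C(=O)c1cc2cnc(Nc3ccc(NC(=O)CCCCCN=C=S)cc3)nc2n1C1CCCC1` — 100%

In a functional assay on A549 cells (Homo sapiens) for inhibition, read by CCK-8 assay, with a stated time of 72 h, tested at 10 uM (on this read-out higher numbers stand for a stronger effect at the one concentration tested and lower numbers for a weaker effect), compound 1 gives 100%, and compound 2 gives 100%. Going by the values given here, the single step in hand, no change at the digits printed from compound 1 to compound 2 (within the scatter), exchanged one linker for another without moving the read-out. Compound 2 therefore stands level with compound 1 at the digits shown; both sit at the top of the scale, so neither can be called the stronger of the two.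

Compound 3, `CN(C)C(=O)c1cc2cnc(Nc3ccc(N=C=S)cc3)nc2n1C1CCCC1`, is not yet measured. It differs from compound 2 as follows: a group of 3 heavy atoms (1 carbon, 1 nitrogen, 1 sulfur; no ring) in place of a group of 11 heavy atoms (7 carbon, 2 nitrogen, 1 oxygen, 1 sulfur; no ring), on an aromatic carbon. The whole chain that carried the isothiocyanate leaves and the isothiocyanate now sits directly on the ring, para to a large group. Among the compounds with values here, no measured step covers a change of this kind; the step from compound 1 to compound 2 only swapped one chain for another of near-equal length, and both values are at the ceiling, so a loss below that ceiling cannot be read from them. The expectation is a small downward step or none beyond the scatter. For compound 3 the expected step is a number 10 percentage points lower from compound 2 to compound 3 (within the scatter). Compound 3 is estimated at 90%, with a range from 60% to 100%.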

Compound 3, a percentage reported as inhibition, at one concentration (the size of the read-out at that concentration, not a potency): 97.9%
Compound 3: the middle estimate sits 7.9 percentage points below what was measured, and the stated range covers the measured number.
By their numbers in this assay, from the lowest: compounds 3, 1 and 2 (each within the scatter of the next).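

In this assay, the step that strips the chain and leaves the isothiocyanate directly on the aromatic carbon, para to a large group, gives a number 2.1 percentage points lower from compound 2 to compound 3 (within the scatter), and the same comparison against the other chain gives a number 2.1 percentage points lower from compound 1 to compound 3 (within the scatter). The earlier pair showed only that one long chain could stand in for another of near-equal size, whereas these steps show that at this position the group of 3 heavy atoms holds the read-out within the scatter of the two chains it replaces, so neither the chain nor its amide is required for the effect at the one concentration tested. Nothing available bears on why the read-out holds across this change.

On these data alone, whether the isothiocyanate itself is needed stays open, since all three compounds carry it and none has an amine or a thiourea on this aromatic carbon in its place. With all three values close to the top of the scale at a single concentration, any difference in potency among them also remains unresolved.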